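Swapping a Carbamate for a Benzoyl Group on a Shared Core

The source may hold more compounds than are shown below. What is called first, only, known or untested is meant among the compounds shown, and "the series" means these compounds.

Measured compounds:
Compound 1, `CCOC(=O)N1CCCc2cc(S(=O)(=O)N3CC(c4ccccc4)NC3=O)ccc21`: 2880 nM
Compound 2, `CCCOC(=O)N1CCCc2cc(S(=O)(=O)N3CC(c4ccccc4)NC3=O)ccc21`: 3920 nM
Compound 3, `CC(C)COC(=O)N1CCCc2cc(S(=O)(=O)N3CC(c4ccccc4)NC3=O)ccc21`: 5650 nM

All three share one core and differ only in the alkyl chain on the carbamate oxygen. In a functional assay on SK-OV-3 cells (Homo sapiens) for antiproliferative activity, read by MTT assay (a lower number here means a stronger inhibitor, a higher number a weaker inhibitor), compound 1 gives 2880 nM, compound 2 gives 3920 nM and compound 3 gives 5650 nM. The steps among them are small: a 1.4-fold higher number from compound 1 to compound 2 (0.13 log units; within the scatter), a 2.0-fold higher number from compound 1 to compound 3 (0.29 log units; within the scatter) and a 1.4-fold higher number from compound 2 to compound 3 (0.16 log units; within the scatter). Among the compounds with values here, compound 3 therefore sits within the scatter of both other compounds, and no compound can be called stronger or weaker than another on these numbers.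

Compound 4, `O=C(c1ccccc1)N1CCCc2cc(S(=O)(=O)N3CC(c4ccccc4)NC3=O)ccc21`, has not yet been measured. It differs from compound 3 as follows: phenyl in place of isobutoxy on a carbonyl carbon. This change removes the carbamate oxygen altogether rather than altering the chain beyond it, so none of the three measured steps covers it directly; they only show that lengthening or branching the alkyl chain left the numbers within scatter. With no measured guide for the loss of the oxygen, the expectation is a number near that of compound 3, with wide uncertainty. Compound 4 is therefore expected to give 4500 nM, with a range from 1500 nM to 14000 nM. This estimate amounts to a step of a 1.3-fold lower number from compound 3 to compound 4 (0.10 log units; within the scatter), which is not expected to exceed the scatter.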

Compound 4, half-maximal inhibitory concentration: 8560 nM
Compound 4: the middle estimate sits 1.9-fold (0.28 log units) below what was measured; measured number inside the range.
By their numbers in this assay, from the lowest: compounds 1, 2, 3 and 4 (each within the scatter of the next, the first and the last beyond it).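

Replacing isobutoxy with phenyl on this carbonyl carbon turns isobutoxycarbonyl into benzoyl, and in this assay this change gives a result that cannot be told apart from the carbamate it replaces (a 1.5-fold higher number from compound 3 to compound 4 (0.18 log units; within the scatter)), so a carbamate oxygen is not needed to stay in the range set by isobutoxy. The shorter carbamates do give the series its first readable differences, modest ones, with phenyl in place of propoxy (a 2.2-fold higher number from compound 2 to compound 4 (0.34 log units; beyond the scatter)) and phenyl in place of ethoxy (a 3.0-fold higher number from compound 1 to compound 4 (0.47 log units; beyond the scatter)), so this swap moves the number in the weaker direction against those two groups but not against isobutoxy. Nothing measured here explains these differences.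

The change removes an oxygen and adds a ring in one move, so the two cannot be separated: benzyloxy on the same carbonyl carbon would keep the oxygen alongside a ring, while a pentyl group would lose the oxygen and carry no ring. Also open, as far as these compounds go, is what a group on the phenyl ring, such as a methoxy group or an amine, would do to the number.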